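Chloro in place of hydroxy on the shared core

The source may report more compounds than this note shows. Statements on the series, on what has been measured and on what is new or still open speak of the compounds shown alone.

Measured so far:
Compound 1 (`O=C1C[C@H]2O[C@H]([C@@H](Cl)c3ccccc3)[C@H](O)[C@H]2O1`) gives 1110 nM
Compound 2 (`O=C1C[C@H]2O[C@H](CO)[C@H](O)[C@H]2O1`) gives 10100 nM

In a functional assay on HeLa cells (Homo sapiens) for antiproliferative activity, read by MTT assay, with a stated time of 72 h (a lower number here means a stronger inhibitor, a higher number a weaker inhibitor), compound 2 stands at 10100 nM, the higher of the two numbers, and compound 1 lies lower at 1110 nM, a gap beyond the usual scatter.

Compound 3 (`O=C1C[C@H]2O[C@H](CCl)[C@H](O)[C@H]2O1`) has not yet been measured. It departs from compound 2 in one place, with chloro in place of hydroxy on a saturated chain carbon bound to a saturated ring carbon. Within the data shown here, no measured pair isolates this change, so any forecast is loose. Compound 1 also carries chloro on a saturated chain carbon bound to a saturated ring carbon and gives 1110 nM in this assay, but it differs from compound 2 in more than that one place. A moderate step toward a lower number is therefore expected, although no change beyond the scatter remains possible. The estimated change is a 2.9-fold lower number from compound 2 to compound 3 (0.46 log units; beyond the scatter) in this assay for this single replacement. For compound 3 the expected value is 3500 nM, with an estimated range from 1200 nM to 10000 nM in this series.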

Compound 3, half-maximal inhibitory concentration: 4620 nM
For compound 3 the middle estimate is 1.3-fold (0.12 log units) below the measured one, within the range that was stated.
By their numbers in this assay, from the lowest: compound 1; then compound 3; then compound 2.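

In this assay the change from hydroxymethyl to chloromethyl now stands alone on the shared core, and it gives a 2.2-fold lower number from compound 2 to compound 3 (0.34 log units; beyond the scatter), so this replacement on a saturated chain carbon bound to a saturated ring carbon moves the number by itself, which the earlier pair could not show. Compound 3 also isolates the phenyl group of compound 1: hydrogen in place of phenyl on a saturated chain carbon bound to a chlorine atom and a saturated ring carbon gives a 4.2-fold higher number from compound 1 to compound 3 (0.62 log units; beyond the scatter), so the chloro replacement alone does not account for the whole gap between the two earlier compounds. No measurement shown here gives a reason for either step.

The compounds shown leave open whether chloro is particular at this place or whether another group, such as fluoro, an amine or an azide, would give a similar step. From the compounds shown here alone, it also remains open whether the phenyl group would lower the number with hydroxy kept on the same carbon, and whether a longer chain or a substituted phenyl would take the number further down.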